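A few compounds are considered here, and "the series" means these few. Any claim that something is new, unique, unknown or untested is made for them only; others in the source may bear on it.

Measured compounds:
- compound 3, `NCCNc1c(C(=O)NCc2ccc(F)cc2)nc(Br)c2cccnc12` — 6000 nM
- compound 1, `O=C(NCc1ccc(F)cc1)c1nc(Br)c2cccnc2c1NCc1ccccc1` — "not determined" (no result reported)
- compound 2, `CS(=O)(=O)Oc1c(C(=O)NCc2ccc(F)cc2)nc(Br)c2cccnc12` — "not determined" (no result reported)

The three compounds above share one core, and only compound 3 carries a number. In a functional assay on MCF7 cells (Homo sapiens) for cytotoxicity, read by MTT assay, with a stated time of 72 h (on this read-out higher numbers stand for weaker inhibition and lower numbers for stronger inhibition), compound 3 gives 6000 nM, which is the sole reference point here; compound 1 and compound 2 were not reported with any result in this assay, so nothing can be said of how they compare.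

Compound 4, `CNCCCNc1c(C(=O)NCc2ccc(F)cc2)nc(Br)c2cccnc12`, is the next entry, still without a measurement. It differs from compound 3 in a single place: (methylamino)methyl in place of amino on a saturated chain carbon, two bonds along the chain from a nitrogen on an aromatic ring. The shared core, the amide and the ring bearing the fluorine are untouched.

For the measured compounds named here, with no measured pair showing a change of this kind, there is no step to lean on. The change is small in what it adds and removes, so the expectation is a step from compound 3 to compound 4 of a 1.2-fold lower number from compound 3 to compound 4 (0.08 log units; within the scatter), no larger than the usual scatter. Compound 4 is therefore estimated at 5000 nM in this assay, with a range from 1500 nM to 15000 nM.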

Compound 4, half-maximal inhibitory concentration: > 10000 nM
Compound 4: only a limit was reported; the forecaster's own chance of this, stated with the estimate: 15%; middle value at least 2.0-fold (0.30 log units) from the limit.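

Replacing amino with (methylamino)methyl on a saturated chain carbon, two bonds along the chain from a nitrogen on an aromatic ring, gives an at least 1.6-fold higher number from compound 3 to compound 4 (0.22 log units; that floor lies within the scatter) in this assay. For the compounds shown here, this is the first look at any change at this position, and it brings no visible gain in cytotoxicity. Compound 4 gives only a limit, so the step has a floor but no known size, and the true value could be close to that of compound 3 or far from it: the limit of > 10000 nM in this assay, at which 1 of the 4 values shown sits.

The compounds shown cannot separate the longer chain from the methyl on the amine, which a 3-aminopropyl chain in the same place could begin to do. On these data alone, how a carboxylic acid at the end of the chain would read also remains open.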